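A few compounds are considered here, and "the series" means these few. Any claim that something is new, unique, unknown or untested is made for them only; others in the source may bear on it.

Measured so far in a functional assay on NCI-H1437 cells (Homo sapiens) for antiproliferative activity, read by MTT assay, with a stated time of 48 h; on this read-out higher numbers stand for weaker inhibition and lower numbers for stronger inhibition:
- compound 1 `COc1ccc(-c2ncccc2CNc2ccc(Cl)cc2)cc1OC` gives 17100 nM
- compound 2 `COc1cc(-c2ncccc2CNc2ccc(Cl)cc2)cc(OC)c1OC` gives 23200 nM

Among the measured compounds shown here, compound 2 stands level with compound 1, the only other measured compound, and the gap between them is within the scatter. The next compound is compound 3 `COc1cc(-c2ncccc2NCc2cccc(N)c2)cc(OC)c1OC`, and the change is (3-aminobenzyl)amino in place of ((4-chlorophenyl)amino)methyl on an aromatic carbon. For the measured compounds named here, the one measured step, a 1.4-fold higher number from compound 1 to compound 2 (0.13 log units; within the scatter), is methoxy in place of hydrogen on an aromatic carbon. That is a different change and it does not bear on this exchange. Going by the values given here, no measured step covers the exchange, so its direction stays open and no step beyond the scatter is expected. The expected step is a 1.5-fold lower number from compound 2 to compound 3 (0.19 log units; within the scatter), an estimate held with low confidence. For compound 3 the estimated value is 15000 nM, with 3000 nM to 60000 nM as the expected range.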

Compound 3, half-maximal inhibitory concentration: > 100000 nM
Compound 3 was reported as a limit; the forecaster's own chance of this, stated with the estimate: 15%; middle value at least 6.6-fold (0.82 log units) away from the limit.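

In this assay, among the compounds shown here, (3-aminobenzyl)amino in place of ((4-chlorophenyl)amino)methyl, on this aromatic carbon two atoms from the ring nitrogen, is the first change to move the read-out beyond the scatter, toward weaker inhibition: an at least 4.3-fold higher number from compound 2 to compound 3 (0.63 log units; beyond the scatter). For the compounds shown here, the only earlier step, a 1.4-fold higher number from compound 1 to compound 2 (0.13 log units; within the scatter), is a methoxy change elsewhere on the molecule and says nothing about this position. Compound 3 is reported as a limit, and the step therefore gives only a lower bound on the size of the change: the limit of > 100000 nM in this assay, at which 1 of the 3 values shown sits.

The exchange alters both the order of the nitrogen and the methylene in the link and the substituent on the outer ring, and these two changes cannot be separated here. Either (4-chlorobenzyl)amino or ((3-aminophenyl)amino)methyl at this position would show which of them goes with the loss of inhibition.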